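Fluoro for Bromo: What to Expect for Compound 4

A few compounds are considered here, and "the series" means these few. Any claim that something is new, unique, unknown or untested is made for them only; others in the source may bear on it.

Compound 1, `COC(=O)[C@@]1(C)CCC=C2[C@@H]1CC[C@@H](C)[C@]2(C)Cc1c(C)[nH]c2c(Cl)cccc12`, in a functional assay on HeLa cells (Homo sapiens) for inhibition, read by sulforhodamine B assay, with a stated time of 48 h (on this read-out lower numbers stand for stronger inhibition of growth and higher numbers for weaker inhibition of growth), gives 17000 nM.
Compound 2, `COC(=O)[C@@]1(C)CC[C@@H]2C3=C1CC[C@@H](C)[C@]3(C)C[C@@H]1c3ccccc3N[C@H]21`, in this assay gives 19000 nM.
Compound 3, `COC(=O)[C@@]1(C)CC[C@@H]2C3=C1CC[C@@H](C)[C@]3(C)C[C@@H]1c3cc(Br)ccc3N[C@H]21`, in this assay gives 25000 nM.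

The three numbers lie close together. Compound 3 has the largest of them, yet its gaps to compound 2 and to compound 1 both fall inside the usual scatter, so the three compounds cannot be told apart on this assay.

Compound 4, `COC(=O)[C@@]1(C)CC[C@@H]2C3=C1CC[C@@H](C)[C@]3(C)C[C@@H]1c3cc(F)ccc3N[C@H]21`, differs from compound 3 by a single change: fluoro in place of bromo on an aromatic carbon. For the measured compounds named here, only one measured step bears on this place. Putting bromo in place of hydrogen there gave a 1.3-fold higher number from compound 2 to compound 3 (0.12 log units; within the scatter). Going by the values given here, no measured pair exchanges fluoro for bromo, so nothing more can be drawn from the data than that a halogen at this place left the number where it was. Compound 4 is therefore expected to show a 1.1-fold lower number from compound 3 to compound 4 (0.06 log units; within the scatter), no step beyond the scatter in either direction. The estimate for compound 4 in this assay is 22000 nM, with a range from 10000 nM to 50000 nM.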

Compound 4, concentration for 50% growth inhibition: 20000 nM
Beside the measured number, compound 4's estimate is 1.1-fold (0.04 log units) above it, and the stated range covers the measured number.
By their numbers in this assay, from the lowest: compounds 1, 2, 4 and 3 (each within the scatter of the next).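

In this assay, fluoro in place of bromo on this aromatic carbon gave a 1.3-fold lower number from compound 3 to compound 4 (0.10 log units; within the scatter), and fluoro in place of hydrogen gave a 1.1-fold higher number from compound 2 to compound 4 (0.02 log units; within the scatter). The earlier compounds offered only hydrogen and bromo at this place; with fluoro added, the two halogens cannot be told apart from each other or from hydrogen on this read-out, so within this small set the place shows no response to the choice among these three atoms. No measurement shown offers an explanation for this result.

Going by these compounds, whether a group of another kind at this place, such as an amine, a methoxy group or a carboxylic acid, would give a step beyond the scatter remains open. Also open, on these data alone, is whether a change elsewhere on the shared core, such as a carboxylic acid in place of the methyl ester, would do so.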